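This account rests on a few compounds, and the source may have more. Where it says the series, first, only, none or still open, it means among the compounds named here.

In a functional assay on MDA-MB-231 cells (Homo sapiens) for inhibition, read by MTT assay, with a stated time of 48 h (on this read-out lower numbers stand for stronger inhibition and higher numbers for weaker inhibition), compound 1 `O=Cc1cccc(OCc2cn(Cc3ccccc3)nn2)c1` gives only a limit, > 50000 nM. Compound 2 `O=C1Nc2ccc(F)cc2/C1=C\c1cccc(OCc2cn(Cc3ccccc3)nn2)c1` likewise returns only a limit in this assay, > 50000 nM. Compound 2 therefore stands at the limit of > 50000 nM in this assay, at which 2 of the 2 values shown sit, and no number separates it from compound 1. Compound 3 `CC(=O)c1ccc2c(c1)/C(=C\c1cccc(OCc3cn(Cc4ccccc4)nn3)c1)C(=O)N2` differs from compound 2 by acetyl in place of fluoro on an aromatic carbon. Going by the values given here, no step between measured compounds is available to guide an expectation for this change, and both values shown are limits rather than numbers. Among the compounds with values here, the expectation is accordingly for no step from compound 2 to compound 3 in this assay beyond the scatter, the estimated step being a step that the limit leaves unreadable from compound 2 to compound 3. For compound 3 the estimate in this assay is 60000 nM, within a range from 20000 nM to 200000 nM, with a limit rather than a number the more likely outcome.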

Compound 3, half-maximal inhibitory concentration: > 50000 nM
Compound 3: a limit, no number; the forecaster's own chance of this, stated with the estimate: 75%; the middle value is on the limit's open side.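

In this assay compound 3 returns only a limit, > 50000 nM. Compound 2 also stands at a limit, so no step can be read from compound 2 to compound 3. The compounds shown give no number, leaving open how acetyl in place of fluoro affects inhibition.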